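The source may report more compounds than this note shows. Statements on the series, on what has been measured and on what is new or still open speak of the compounds shown alone.

Compound 1, `COc1ccc(C2CC(c3cc4ccccc4o3)=NN2C(=O)c2ccncc2)c(O)c1`: > 190000 nM
Compound 2, `CCn1cc(C(=O)N2N=C(c3cc4ccccc4o3)CC2c2ccccc2OC)c(=O)c2ccc(C)nc21`: > 187000 nM

Both numbers come from an ADME assay on Vero cells (Chlorocebus sabaeus) for cytotoxicity, read by MTT assay, with a stated time of 72 h; a lower number here means a stronger inhibitor, a higher number a weaker inhibitor. Compound 1 gives > 190000 nM in this assay, which is a limit of the assay and not a measured number, and it sits at the limit of > 190000 nM in this assay, at which 1 of the 2 values shown sits. Compound 2 gives > 187000 nM in this assay, again a limit rather than a number, and it sits at the limit of > 187000 nM in this assay, at which 1 of the 2 values shown sits. Where compound 2 stands can therefore only be said as this: no inhibition was found up to the limit, and the same holds for compound 1, so the two values cannot be placed in any order.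

Compound 3 is `CCn1cc(C(=O)N2N=C(c3cc4ccccc4o3)CC2c2ccc(Cl)cc2)c(=O)c2ccc(C)nc21`, not yet measured in this assay. It differs from compound 2 by 4-chlorophenyl in place of 2-methoxyphenyl on a saturated ring carbon. Among the measured compounds shown here, no measured step between two compounds exists here to lean on. The expectation is that compound 3 stays at the limit as well, so the step from compound 2 to compound 3 is expected to be a step that the limit leaves unreadable from compound 2 to compound 3, nothing beyond the scatter. Compound 3 is expected to give about 190000 nM in this assay, within 100000 nM to 400000 nM.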

Compound 3, half-maximal inhibitory concentration: > 160000 nM
Compound 3 ended at the assay's limit; the forecaster's own chance of this, stated with the estimate: 85%; the middle value lies beyond the limit too.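

In this assay compound 3 gives > 160000 nM, which is a limit of the assay and not a number. Among the compounds shown here, compound 2 also sits at a limit, so no step from compound 2 to compound 3 can be read. The compounds shown leave open whether any of them harms these cells at a higher concentration, and whether 4-chlorophenyl in place of 2-methoxyphenyl changes that.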